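This account rests on a few compounds, and the source may have more. Where it says the series, first, only, none or still open, it means among the compounds named here.

In a functional assay on the whole organism (strain Wistar) with Rattus norvegicus as the target, with a stated time of 5 min (on this read-out lower numbers stand for an effect already at smaller amounts and higher numbers for an effect only at larger amounts of compound), three compounds have been measured so far:

Compound 1 `CCC1(CCCCN2CCN(c3ccc(F)cc3)CC2)C(=O)Nc2ccccc21` gives 10 mg/kg.
Compound 2 `CCC1(CCCCN2CCN(c3ccc(F)c(Cl)c3)CC2)C(=O)Nc2ccccc21` gives only a limit of the assay, > 20 mg/kg.
Compound 3 `CCC1(CCCCN2CCN(c3ccccc3)CC2)C(=O)Nc2ccccc21` gives 10 mg/kg.

The change from compound 1 to compound 2 is chloro in place of hydrogen on an aromatic carbon. It brought an at least 2.0-fold higher number from compound 1 to compound 2 (0.30 log units; that floor lies within the scatter), and the size of that step is only a floor because of the limit of > 20 mg/kg in this assay, at which 1 of the 3 values shown sits. Compound 1 and compound 3 differ by hydrogen in place of fluoro on an aromatic carbon, which gave no change at the digits printed from compound 1 to compound 3 (within the scatter).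

Compound 4 `CCC1(CCCCN2CCN(c3cccc(Cl)c3)CC2)C(=O)Nc2ccccc21` is not yet measured. It stands to compound 3 as compound 2 stands to compound 1: the difference is chloro in place of hydrogen on an aromatic carbon. The surroundings are not the same, though: in compound 2 the entering chloro is also ortho to a fluoro group, while in compound 4 it is only meta to a large group, so this is the same kind of change rather than the same change.

Resting on the step from compound 1 to compound 2, an at least 2.0-fold higher number from compound 1 to compound 2 (0.30 log units; that floor lies within the scatter), a step of a 2.0-fold higher number from compound 3 to compound 4 (0.30 log units; within the scatter) is expected here. Compound 4 is therefore estimated at 20 mg/kg, with a range from 10 mg/kg to 40 mg/kg.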

Compound 4, minimum effective dose: > 20 mg/kg
Compound 4 ended at the assay's limit (the forecaster's own chance of this, stated with the estimate: 50%); the middle value sits exactly at the limit.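

Chloro in place of hydrogen on the aromatic ring gave an at least 2.0-fold higher number from compound 3 to compound 4 (0.30 log units; that floor lies within the scatter) in this assay, and set beside the earlier case, the two results agree in direction only: the same change on two cores in this assay, an at least 2.0-fold higher number (0.30 log units; that floor lies within the scatter) from compound 1 to compound 2 and an at least 2.0-fold higher number (0.30 log units; that floor lies within the scatter) from compound 3 to compound 4; the limit leaves it open whether they differ

Compound 4 gives > 20 mg/kg, which is a limit of the assay and not a number.

On these data alone, the change therefore carried from one core to the other with the same direction, but its size on either core remains unknown and each floor lies within the scatter; the wider swap gives an at least 2.0-fold higher number from compound 1 to compound 4 (0.30 log units; that floor lies within the scatter), and the step between compound 2 and compound 4 cannot be read, with both at a limit.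

As far as these compounds go, it remains open whether a methyl or a methoxy group in place of the chloro would leave the number level with compound 3 at 10 mg/kg. A longer chain between the shared core and the ring amine is also untested among the compounds shown here.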